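Amine exchange on the shared core: compound 3 to compound 4

The source may report more compounds than this note shows. Statements on the series, on what has been measured and on what is new or still open speak of the compounds shown alone.

Measured so far in an assay on isolated protein for inhibition of protein deacetylase HDAC6 (Homo sapiens), tested at 0.5 uM; on this read-out lower numbers stand for less inhibition and higher numbers for more inhibition at the one concentration tested (going by the name of the read-out):
compound 1 `O=C(NO)c1ccc(-c2nc(N3CCC(F)(F)CC3)c3ccccc3n2)cc1` — 71.7%
compound 2 `O=C(NO)c1ccc(-c2nc(N3CCCC3)c3ccc(Cl)cc3n2)cc1` — 54.6%
compound 3 `CN1CCN(c2nc(-c3ccc(C(=O)NO)cc3)nc3cc(Cl)ccc23)CC1` — 94.4%

Compound 3 stands highest of the three numbers, beyond the scatter from both compound 1 and compound 2. Among the compounds with values here, the one step, a number 39.8 percentage points higher from compound 2 to compound 3 (beyond the scatter), shows that the amine on the aromatic carbon moves the read-out strongly.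

Compound 4 `O=C(NO)c1ccc(-c2nc(N3CCC(F)(F)CC3)c3ccc(Cl)cc3n2)cc1` differs from compound 3 as follows: 4,4-difluoropiperidin-1-yl in place of 4-methylpiperazin-1-yl on an aromatic carbon. Within the data shown here, no measured step covers this exchange. Compound 1 carries the same entering group on a core without chlorine and gives 71.7%, well under compound 3. Compound 4 is therefore expected to lie below compound 3, by about a number 24.4 percentage points lower from compound 3 to compound 4 (beyond the scatter), an estimate near 70% with a range of 50% to 88%.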

Compound 4, a percentage reported as inhibition, at one concentration (the size of the read-out at that concentration, not a potency): 64.6%
Beside the measured number, compound 4's estimate is 5.4 percentage points above it; the range from low to high includes it.
By their numbers in this assay, from the lowest: compounds 2, 4 and 1 (each within the scatter of the next, the first and the last beyond it); then compound 3.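

In this assay the exchange of 4-methylpiperazin-1-yl for 4,4-difluoropiperidin-1-yl gives a number 29.8 percentage points lower from compound 3 to compound 4 (beyond the scatter) at this position, so not every six-membered non-aromatic ring matches compound 3 here. Against pyrrolidin-1-yl, 4,4-difluoropiperidin-1-yl gives a number 10 percentage points higher from compound 2 to compound 4 (within the scatter) and chloro in place of hydrogen gives a number 7.1 percentage points lower from compound 1 to compound 4 (within the scatter) on the shared core, so neither exchange separates its pair. Nothing at hand gives a reason for the gap between these amines.

Open, on these data alone, is whether piperazin-1-yl without the methyl, or morpholin-4-yl, holds the number of compound 3 at this position. Also open, as far as these compounds go, is whether chloro in place of hydrogen reads the same alongside 4-methylpiperazin-1-yl.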